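Pyridin-4-yl on the ring amide nitrogen of compound 1

A few compounds are considered here, and "the series" means these few. Any claim that something is new, unique, unknown or untested is made for them only; others in the source may bear on it.

Compound 1 `O=C1NC(=O)C2(CSC3=C2C(=O)c2ncccc2C3=O)N1` gives 3120 nM in a functional assay on XF498 cells (Homo sapiens) for antiproliferative activity, read by MTT assay, with a stated time of 96 h (on this read-out lower numbers stand for stronger inhibition and higher numbers for weaker inhibition), which is the second highest of three numbers; its nearest neighbour is compound 3 `O=C1NN(c2ccc(Cl)cc2)C(=O)C2(CSC3=C2C(=O)c2ncccc2C3=O)N1` at 2500 nM, and compound 2 `O=C1NN(c2ccc([N+](=O)[O-])cc2)C(=O)C2(CSC3=C2C(=O)c2ncccc2C3=O)N1` gives 4800 nM. Between these two the only single-point step, a 1.9-fold lower number from compound 2 to compound 3 (0.28 log units; within the scatter), stays within the scatter, so the series gives no step larger than noise. Compound 4 `O=C1C2=C(C(=O)c3ncccc31)C1(CS2)NC(=O)N(c2ccncc2)C1=O` differs from compound 1 by pyridin-4-yl in place of hydrogen on an amide-type nitrogen in a ring. Among the measured compounds shown here, no measured pair shows an aryl group entering at this nitrogen, so the step has no direct precedent; the only comparable substitution, the aryl variation between compound 2 and compound 3, moved the number little. For compound 4 the expectation is therefore no change beyond the scatter, a 1.0-fold lower number from compound 1 to compound 4 (0.02 log units; within the scatter), giving an estimated 3000 nM with a range from 1400 nM to 6500 nM.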

Compound 4, half-maximal inhibitory concentration: 1120 nM
For compound 4 the middle estimate is 2.7-fold (0.43 log units) above the measured one; the measured number lies below the stated range.
By their numbers in this assay, from the lowest: compound 4; then compounds 3, 1 and 2 (each within the scatter of the next).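

Pyridin-4-yl in place of hydrogen on the amide-type nitrogen in a ring gives the only step in the series beyond the scatter, seen in this assay as a 2.8-fold lower number from compound 1 to compound 4 (0.44 log units; beyond the scatter). This nitrogen therefore tolerates an aromatic ring, and the number moves lower with this group in place. No measurement at hand accounts for the step.

Still open, as far as these compounds go, is whether the ring nitrogen of the pyridine matters, which phenyl or pyridin-3-yl at this position would test. Also open, from the compounds shown here alone, is how a non-aromatic group, such as a 2-aminoethyl chain, would fare here.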